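From a Benzyl Urea to a Difluorophenyl Amide: Cytotoxicity

The compounds below may be only part of what the source reports. "The series", "measured", "known", "first", "only" and "open" are said of these compounds alone.

Compound 1 `CCN(CC)c1cc2[nH]c(C3CCCCC3)nc2cc1NC(=O)NCc1ccccc1` carries a benzylamino urea and a diethylamino group on the shared core. In an ADME assay on Vero cells (Chlorocebus sabaeus) for cytotoxicity, read by resazurin assay, with a stated time of 3 days (on this read-out lower numbers stand for stronger inhibition and higher numbers for weaker inhibition), compound 1 gives > 100 ug/mL, which is a limit of the assay rather than a number. Compound 2 `O=C(NCc1ccccc1)Nc1cc2nc(C3CCCCC3)[nH]c2cc1N1CCCC1` differs from compound 1 only by pyrrolidin-1-yl in place of diethylamino on an aromatic carbon. In this assay compound 2 gives > 100 ug/mL, again a limit. The step that the two limits leave unreadable from compound 1 to compound 2 is therefore unreadable. Compound 3 `CCCOCC(=O)Nc1cc2nc(C3CCCCC3)[nH]c2cc1N(C)C` is built on the same core with other groups. In this assay compound 3 gives < 50 ug/mL, also a limit. Among the measured compounds shown here, two of the three values sit at the limit of > 100 ug/mL in this assay, at which 2 of the 3 values shown sit, and one at the limit of < 50 ug/mL in this assay, at which 1 of the 3 values shown sits, so no measured step has a readable size.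

The change from compound 1 to compound 4 `CCN(CC)c1cc2[nH]c(C3CCCCC3)nc2cc1NC(=O)c1ccc(F)cc1F` is 2,4-difluorophenyl in place of benzylamino on a carbonyl carbon. For the measured compounds named here, none of the measured steps touches this carbonyl position, and the single step that exists could not be read, so there is no guide to the direction or size of this change in this assay. With nothing to lean on, compound 4 is expected to land near the limits of this assay, estimated at 90 ug/mL, between 45 ug/mL and 180 ug/mL. The expected step from the starting point is an at least 1.1-fold lower number from compound 1 to compound 4 (0.04 log units; that floor lies within the scatter).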

Compound 4, half-maximal inhibitory concentration: > 100 ug/mL
Compound 4: no number, only a limit; the forecaster's own chance of this, stated with the estimate: 60%; at least 1.1-fold (0.04 log units) between middle value and limit.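

In this assay, among the compounds shown here, compound 4 gives > 100 ug/mL, which is a limit and not a number, and compound 1 also stands at a limit, so no step from compound 1 to compound 4 can be read. The compounds shown leave open whether 2,4-difluorophenyl in place of benzylamino on a carbonyl carbon changes cytotoxicity at all.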